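Isoquinoline attachment point in the urea series

A few compounds are considered here, and "the series" means these few. Any claim that something is new, unique, unknown or untested is made for them only; others in the source may bear on it.

compound 1 `CN(C)C1(Cc2ccccc2)CCN(c2cc(C(F)(F)F)ccc2CNC(=O)Nc2cccc3c(=O)[nH]ccc23)CC1` in an assay on CHO cells for antagonist activity at transient receptor potential cation channel subfamily V member 1 (Homo sapiens), read by scintillation counting, with a stated time of 5 min, in the presence of a further agent that is not named here (a lower number here means that less compound is needed, a higher number that more compound is needed for the effect), gives "not active" (no number reported)
compound 2 `CN(C)C1(Cc2ccccc2)CCN(c2cc(C(F)(F)F)ccc2CNC(=O)Nc2ccc3cccnc3c2)CC1` in this assay gives 42 nM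
compound 3 `CN(C)C1(Cc2ccccc2)CCN(c2cc(C(F)(F)F)ccc2CNC(=O)Nc2ccc3cnccc3c2)CC1` in this assay gives 156 nM

Compound 3 stands highest of the two numbers in this assay; compound 2 sits at the lower number, and for compound 1 no number is reported. Compound 4 `CN(C)C1(Cc2ccccc2)CCN(c2cc(C(F)(F)F)ccc2CNC(=O)Nc2cccc3cnccc23)CC1` differs from compound 3 by isoquinolin-5-yl in place of isoquinolin-6-yl on an amide-type nitrogen. For the measured compounds named here, no measured step shifts the ring nitrogen within an isoquinoline. Going by the values given here, the only step on this nitrogen, a 3.7-fold higher number from compound 2 to compound 3 (0.57 log units; beyond the scatter), changed the whole group and was modest, so a step of similar size, in either direction, is the reasonable expectation. The expected step is a 1.6-fold higher number from compound 3 to compound 4 (0.20 log units; within the scatter), direction uncertain. Compound 4 is therefore estimated at 250 nM, with a range from 60 nM to 1000 nM.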

Compound 4, half-maximal effective concentration: 8.8 nM
Compound 4: the middle estimate sits 28-fold (1.45 log units) above what was measured; measured number below the stated range.
By their numbers in this assay, from the lowest: compound 4; then compound 2; then compound 3.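

Moving the attachment point within the isoquinoline matters at this position: in this assay, the same atoms joined differently give an 18-fold lower number from compound 3 to compound 4 (1.25 log units; beyond the scatter), a large step where the earlier step on this nitrogen was modest. Isoquinolin-5-yl in place of quinolin-7-yl gives a 4.8-fold lower number from compound 2 to compound 4 (0.68 log units; beyond the scatter), so compound 4 holds the lowest number of the three measured.

Open, from the compounds shown here alone, is whether the ring nitrogen of compound 4 is needed at all, which a naphthalen-1-yl group on the same nitrogen would test. No measurement shown accounts for the gap between the isoquinolines.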